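Hydroxy to amino on the side-chain carbon of compound 1

The compounds below may be only part of what the source reports. "The series", "measured", "known", "first", "only" and "open" are said of these compounds alone.

The series shares the core of compound 1 `CC(C)(C)C1=C(C(=O)O)N2C(=O)[C@H](CO)[C@H]2O1` and is varied only on the saturated chain carbon bound to a saturated ring carbon. In an ADME assay, in phosphate buffer, at 28 degrees C, at pH 7.0 (a lower number here means that the compound disappears faster, a higher number that the compound lasts longer), compound 1 gives 5 h, the lowest of the three numbers measured. Compound 2 `CC(C)(C)C1=C(C(=O)O)N2C(=O)[C@H]([C@@H](O)c3ccncc3)[C@H]2O1` gives 6 h and compound 3 `CC(C)(C)C1=C(C(=O)O)N2C(=O)[C@H]([C@@H](O)CCc3ccncc3)[C@H]2O1` gives 15.8 h. The step of a 1.2-fold higher number from compound 1 to compound 2 (0.08 log units; within the scatter) is within the scatter, while a 3.2-fold higher number from compound 1 to compound 3 (0.50 log units; beyond the scatter) and a 2.6-fold higher number from compound 2 to compound 3 (0.42 log units; beyond the scatter) are modest.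

Compound 4 `CC(C)(C)C1=C(C(=O)O)N2C(=O)[C@H](CN)[C@H]2O1` differs from compound 1 by amino in place of hydroxy on a saturated chain carbon bound to a saturated ring carbon. Going by the values given here, none of the measured steps swaps the hydroxy itself; all three keep it and only add pyridin-4-yl or 2-(pyridin-4-yl)ethyl on that chain carbon, so they do not bear directly on this change. Among the compounds with values here, with no precedent for the exchange, no step beyond the scatter is assumed in this assay, in either direction. Compound 4 is therefore expected at 5 h, with a range from 2.5 h to 10 h. The step of no change at the digits printed from compound 1 to compound 4 (within the scatter) is estimated to stay within the scatter.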

Compound 4, half-life: 1.2 h
Compound 4: middle estimate off by 4.2-fold (0.62 log units), on the high side; measured number outside the range, below it.
By their numbers in this assay, from the lowest: compound 4; then compounds 1 and 2 (each within the scatter of the next); then compound 3.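

In this assay, going by these compounds alone, amino in place of hydroxy on a saturated chain carbon bound to a saturated ring carbon gives a 4.2-fold lower number from compound 1 to compound 4 (0.62 log units; beyond the scatter), so the identity of this single heavy atom affects the number, whereas the earlier steps all kept hydroxy and gave either no change beyond the scatter or a higher number. The computed counts of hydrogen-bond donors and acceptors and the net charge are the same for hydroxy and amino, so these counts do not separate the two groups. No supporting measurement is available to explain the lower number.

From the compounds shown here alone, it remains open whether amino in place of hydroxy would lower the numbers of compound 2 and compound 3 in the same way. A methoxy, a methylamino or a longer aminoethyl chain also remains to be placed against compound 1.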